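This account rests on a few compounds, and the source may have more. Where it says the series, first, only, none or still open, it means among the compounds named here.

In an assay on HEK293 cells for agonist activity at Toll-like receptor 8 (Homo sapiens), read by spectrophotometry (a higher number here means that more compound is needed for the effect, a lower number that less compound is needed), two compounds from this series have numbers. For the measured compounds named here, compound 1 `CCCCNc1nc(N)nc(C)c1CCCN1CCCCC1` gives 133 nM, and compound 2 `CCCCNc1nc(N)nc(C)c1CCCC(C)(C)O` gives 1220 nM, which is the higher of the two; the only measured step, a 9.2-fold higher number from compound 1 to compound 2 (0.96 log units; beyond the scatter), separates them. Compound 3 `CCCCCc1c(C)nc(N)nc1NCCCC` has not yet been measured. It differs from compound 2 by ethyl in place of 1-hydroxy-1-methylethyl on a saturated chain carbon, three bonds along the chain from an aromatic carbon. Going by the values given here, no measured step in this assay removes the hydroxyl group in this way, so nothing bears on it directly; the one step that is known, a 9.2-fold higher number from compound 1 to compound 2 (0.96 log units; beyond the scatter), changed the same position, which gives a sense of scale but not of direction. The step of a 1.6-fold higher number from compound 2 to compound 3 (0.21 log units; within the scatter) is therefore expected to be modest, with a slightly higher number thought more likely. Compound 3 is estimated at 2000 nM, within a range from 500 nM to 8000 nM.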

Compound 3, half-maximal effective concentration: 1220 nM
For compound 3 the middle estimate is 1.6-fold (0.21 log units) above the measured one; the measured number falls inside the stated range.
By their numbers in this assay, from the lowest: compound 1; then compounds 2 and 3 (each within the scatter of the next).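

In this assay, no change at the digits printed from compound 2 to compound 3 (within the scatter), so compounds 2 and 3 cannot be told apart even though ethyl replaces 1-hydroxy-1-methylethyl and the hydrogen-bond donor and acceptor of that group are gone. For the compounds shown here, compound 1 now stands apart from two different replacements of its piperidin-1-yl group, since a 9.2-fold higher number from compound 1 to compound 3 (0.96 log units; beyond the scatter), a step as large as the one to the hydroxyl-bearing compound 2. No measured evidence is available to explain these numbers.

On these data alone, whether the lower number of compound 1 goes with the piperidine ring or with its amine nitrogen stays open; a cyclohexyl ring and an open-chain amine such as diethylamino at this place on the chain would separate the two. As far as these compounds go, what a carboxylic acid at the same place would give also stays open.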